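Replacing the Benzylsulfanyl Group of Compound 2

The source may hold more compounds than are shown below. What is called first, only, known or untested is meant among the compounds shown, and "the series" means these compounds.

Measured in a functional assay on HL-60 cells (Homo sapiens) for inhibition, read by XTT assay, with a stated time of 72 h; a higher number here means a weaker inhibitor, a lower number a stronger inhibitor:
- compound 1 `CN(Cc1ncnc2c1ncn2[C@@H]1O[C@H](CO)[C@@H](O)[C@H]1O)c1ccccc1`: 3400 nM
- compound 2 `OC[C@H]1O[C@@H](n2cnc3c(CSCc4ccccc4)ncnc32)[C@H](O)[C@@H]1O`: 19200 nM

Of these two compounds, compound 2 holds the higher number at 19200 nM, which makes it the weaker inhibitor. The next compound, compound 3 `OC[C@H]1O[C@@H](n2cnc3c(COc4ccccn4)ncnc32)[C@H](O)[C@@H]1O`, keeps the shared core and changes one group: (pyridin-2-yl)oxy in place of benzylsulfanyl on a saturated chain carbon bound to an aromatic carbon. Among the compounds with values here, only one measured step bears on this change. It is a 5.6-fold higher number from compound 1 to compound 2 (0.75 log units; beyond the scatter), and it also exchanged the group on the saturated chain carbon bound to an aromatic carbon. Within the data shown here, no measured compound carries (pyridin-2-yl)oxy, so the direction remains uncertain. A modest step toward a lower number in this assay is expected, smaller than that measured one. The expected step is a 2.4-fold lower number from compound 2 to compound 3 (0.38 log units; beyond the scatter). For compound 3 the estimated value is 8000 nM, with an expected range from 2000 nM to 30000 nM.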

Compound 3, half-maximal inhibitory concentration: 14300 nM
Beside the measured number, compound 3's estimate is 1.8-fold (0.25 log units) below it; the range from low to high includes it.
By their numbers in this assay, from the lowest: compound 1; then compounds 3 and 2 (each within the scatter of the next).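

In this assay, exchanging benzylsulfanyl for (pyridin-2-yl)oxy on the saturated chain carbon bound to an aromatic carbon gives a 1.3-fold lower number from compound 2 to compound 3 (0.13 log units; within the scatter), so this change, which brings in a ring with 1 hetero atom, does not separate the two groups. Methyl(phenyl)amino remains the group with the lowest number among the three, as the second group also falls short of it, with a 4.2-fold higher number from compound 1 to compound 3 (0.62 log units; beyond the scatter), and the gap first seen with benzylsulfanyl therefore holds for two different replacements. No supporting data explain these differences.

As far as these compounds go, compound 1 alone carries an amine on this carbon, so it remains open whether a smaller amine such as dimethylamino would match it. From the compounds shown here alone, the effect of a longer chain carrying the phenyl ring also remains open.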